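The source may report more compounds than this note shows. Statements on the series, on what has been measured and on what is new or still open speak of the compounds shown alone.

Three compounds of the series have been run in an assay on membranes from CHO cells for displacement of a labelled ligand from adenosine receptor A1 (Homo sapiens), read by scintillation counting, with a stated time of 60 min, tested at 1 uM; a lower number here means less inhibition, a higher number more inhibition at the concentration tested (going by the name of the read-out). Compound 1 `CCN(CC)C(=O)C1=C(C)NC(=O)NC1c1ccco1` gives 11%, compound 2 `CCN(CC)C(=O)C1=C(C)NC(=O)NC1c1ccoc1` gives 15%, and compound 3 `CCN(CC)C(=O)C1=C(C)NC(=O)NC1c1cccs1` gives 13%. Compound 1 has the lowest of the three numbers, though all three lie within the scatter of one another: its nearest neighbour is compound 3, with a number 2 percentage points higher from compound 1 to compound 3 (within the scatter), and the furthest is compound 2, with a number 4 percentage points higher from compound 1 to compound 2 (within the scatter); the remaining pair shows a number 2 percentage points lower from compound 2 to compound 3 (within the scatter). Each of these steps exchanges the furan-2-yl, furan-3-yl or thiophen-2-yl group on the saturated ring carbon, and none moves beyond the scatter, so the shared core sits at a low level of inhibition throughout.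

Compound 4 `CC1=C(C(=O)OC2CCC2)C(c2ccco2)NC(=O)N1` has not been measured. Relative to compound 1 the change is cyclobutyloxy in place of diethylamino on a carbonyl carbon. For the measured compounds named here, no measured step touches the carbonyl carbon; the three known steps alter a different part of the molecule and all stay within the scatter, so they give no direct guide to the size or direction of this change. With low inhibition in every measured analogue, compound 4 is expected to remain in the same region, with a number 1 percentage points higher from compound 1 to compound 4 (within the scatter) expected to lie within the scatter. The estimate for compound 4 in this assay is 12%, with a range from 0% to 30%.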

Compound 4, a percentage reported as inhibition, at one concentration (the size of the read-out at that concentration, not a potency): 19%
Compound 4: middle estimate off by 7 percentage points, on the low side; the range from low to high includes it.
By their numbers in this assay, from the lowest: compounds 1, 3, 2 and 4 (each within the scatter of the next).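

For the compounds shown here, at the carbonyl carbon, which no earlier step touched, in this assay cyclobutyloxy in place of diethylamino gives a number 8 percentage points higher from compound 1 to compound 4 (within the scatter), so an exchange of the whole substituent at this position, with the same heavy-atom count, still leaves compound 4 within the scatter of compound 1. The exchanges on the saturated ring carbon also stayed within the scatter, so changes at two separate places have not yet set any compound apart from compound 1. No measurement on hand accounts for the outcome of this exchange.

This single step swaps nitrogen for oxygen and brings in a four-membered ring together, so the two changes cannot be told apart. On these data alone, it remains open whether ethoxy, a carboxylic acid or piperidin-1-yl on the carbonyl carbon would carry the number beyond the scatter.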